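This account rests on a few compounds, and the source may have more. Where it says the series, first, only, none or still open, it means among the compounds named here.

Measured so far in a functional assay on CAPAN-1 cells (Homo sapiens) for antiproliferative activity; a lower number here means a stronger inhibitor, a higher number a weaker inhibitor
- compound 1 `CNc1cc(-c2ccc3cnn(Cc4cc(OC)cc(OC)c4)c3c2)cn(C)c1=O` gives 3800 nM
- compound 2 `CNc1cc(-c2ccc3cnn(Cc4ccc(F)c(F)c4)c3c2)cn(C)c1=O` gives 3700 nM
- compound 3 `CNc1cc(-c2ccc3cnn(Cc4ccc(F)c([N+](=O)[O-])c4)c3c2)cn(C)c1=O` has no value yet

Going by the values given here, compound 2 stands level with compound 1 on these numbers, since the only measured step is a 1.0-fold lower number from compound 1 to compound 2 (0.01 log units; within the scatter) and it stays within the scatter. The change to compound 3 nitro in place of fluoro on an aromatic carbon is nitro in place of fluoro on an aromatic carbon, ortho to a fluoro group and meta to a large group, so 3,4-difluorophenyl becomes 4-fluoro-3-nitrophenyl. Among the compounds with values here, no measured compound carries nitro, so the data hold no direct precedent for this group. Within the data shown here, the one step that bears on it also changes the substituted phenyl, and it is small. That is thin support from a single pair, but it gives no reason to expect a large move from compound 2. What is expected is a 1.2-fold lower number from compound 2 to compound 3 (0.09 log units; within the scatter) in this assay with nothing beyond the scatter. Compound 3 is estimated at 3000 nM with an expected range of 1200 nM to 8000 nM in this assay for now.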

Compound 3, half-maximal inhibitory concentration: 4000 nM
Beside the measured number, compound 3's estimate is 1.3-fold (0.12 log units) below it; low and high end bracket the measured number.
By their numbers in this assay, from the lowest: compounds 2, 1 and 3 (each within the scatter of the next).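

In this assay, nitro in place of fluoro on an aromatic carbon, ortho to a fluoro group and meta to a large group, gives a 1.1-fold higher number from compound 2 to compound 3 (0.03 log units; within the scatter), so a group of 3 heavy atoms with 2 hydrogen-bond acceptors is tolerated here in place of 1 heavy atom with none, without any readable shift. The wider replacement of the substituted phenyl gives a 1.1-fold higher number from compound 1 to compound 3 (0.02 log units; within the scatter), so 3,5-dimethoxyphenyl, 3,4-difluorophenyl and 4-fluoro-3-nitrophenyl on the saturated chain carbon all read level, and the flat reading now rests on three compounds rather than a single pair. No available evidence accounts for this flat reading.

Still open is whether an amine or a carboxylic acid in place of the nitro would move the number at all, given that every phenyl group shown reads alike. Also open is whether a longer chain between the aromatic nitrogen and the phenyl, or a change on the shared core, would separate compounds that the phenyl substituents shown leave level.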